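Chain length on the ring nitrogen in the urea series

A few compounds are considered here, and "the series" means these few. Any claim that something is new, unique, unknown or untested is made for them only; others in the source may bear on it.

Compound 1 `CC(C)c1cccc(C(C)C)c1NC(=O)NC1=NN(Cc2ccccc2)NN1` gives 370 nM in an assay on microsomes from intestine for inhibition of acyl-CoA:cholesterol acyltransferase (Oryctolagus cuniculus); on this read-out lower numbers stand for stronger inhibition and higher numbers for weaker inhibition. Compound 2 `CCCCCCCCCN1NN=C(NC(=O)Nc2c(C(C)C)cccc2C(C)C)N1` gives 31 nM in this assay, and compound 3 `CCCCCCCCCCCCN1NN=C(NC(=O)Nc2c(C(C)C)cccc2C(C)C)N1` gives 14 nM. Among these three numbers compound 2 stands second highest, nearest to compound 3 and furthest from compound 1. Among the compounds with values here, the only single-site step available is a 2.2-fold lower number from compound 2 to compound 3 (0.35 log units; beyond the scatter), a modest move. Compound 4 `CCCCCCCCCCCCCCCCN1NN=C(NC(=O)Nc2c(C(C)C)cccc2C(C)C)N1` differs from compound 2 by heptyl in place of hydrogen on a saturated chain carbon, nine bonds along the chain from an amine nitrogen in a ring. This change runs in the same direction as the step already seen but goes further, so in this assay a step to a lower number of similar or somewhat larger size is expected, without certainty that the gain keeps pace with the chain. For compound 4 the estimate is 10 nM with a range from 4 nM to 30 nM, which means an expected 3.1-fold lower number from compound 2 to compound 4 (0.49 log units; beyond the scatter).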

Compound 4, half-maximal inhibitory concentration: 57 nM
Compound 4: middle estimate off by 5.7-fold (0.76 log units), on the low side; measured number outside the range, above it.
By their numbers in this assay, from the lowest: compound 3; then compounds 2 and 4 (each within the scatter of the next); then compound 1.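

In this assay lengthening at this position does not keep lowering the number: butyl in place of hydrogen on a saturated chain carbon gives a 4.1-fold higher number from compound 3 to compound 4 (0.61 log units; beyond the scatter) and runs against the earlier step. Heptyl in place of hydrogen, nine bonds along the chain, gives a 1.8-fold higher number from compound 2 to compound 4 (0.26 log units; within the scatter) and leaves that pair indistinguishable. Among these three chains, compound 3 therefore sits at a low point rather than on a steady trend.

On these data alone, whether a tetradecyl chain lies closer to compound 3 or compound 4 remains open, as does the effect of a terminal amine or carboxylic acid on the chain. As far as these compounds go, what underlies the reversal also stays open, with no supporting information to hand.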